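A 4-Methylpiperazin-1-yl Group on the Shared Core

The source may report more compounds than this note shows. Statements on the series, on what has been measured and on what is new or still open speak of the compounds shown alone.

In an ADME assay on microsomes from liver (Mus musculus) for metabolic stability, read by LC-MS, with a stated time of 10 min (a higher number here means that more of the compound is left, a lower number that less of the compound is left), two compounds built on one shared core have been measured. Compound 1 `CN(C[C@H]1Cc2c(cccc2N2CCN(Cc3ccccn3)CC2)CN1)[C@H]1CCCc2cccnc21` gives 40.4% and compound 2 `CN(C[C@H]1Cc2c(cccc2N2CCN3CCC[C@@H]3C2)CN1)[C@H]1CCCc2cccnc21` gives 36.7% in this read-out, so compound 2 stands within the usual scatter of compound 1. Compound 3 `CN1CCN(c2cccc3c2C[C@H](CN(C)[C@H]2CCCc4cccnc42)NC3)CC1` differs from compound 2 on an aromatic carbon of a six-membered aromatic ring of carbon only, with the change a group of 7 heavy atoms (5 carbon, 2 nitrogen; one six-membered non-aromatic ring with 2 hetero atoms) in place of a group of 9 heavy atoms (7 carbon, 2 nitrogen; one five-membered non-aromatic ring with 1 hetero atom, one six-membered non-aromatic ring with 2 hetero atoms), on an aromatic carbon as the sole difference. For the measured compounds named here, no measured pair differs in one place only, so the data show no such step directly. The expectation rests on compound 1, which carries another group at that carbon and gives 40.4% within the scatter of compound 2. In this assay the estimated step is a number 3.3 percentage points higher from compound 2 to compound 3 (within the scatter) and it is expected to stay within the scatter. The estimated value for compound 3 is 40% with an expected range from 22% to 60% once it is measured.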

Compound 3, percent of the compound remaining: 17%
Beside the measured number, compound 3's estimate is 23 percentage points above it; the measured number lies below the stated range.
By their numbers in this assay, from the lowest: compound 3; then compounds 2 and 1 (each within the scatter of the next).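

In this assay, the aromatic carbon that carries these groups proves sensitive to the group placed there: compounds 1 and 2 stand within the scatter of each other, but 4-methylpiperazin-1-yl in place of the group of 9 heavy atoms gives a number 19.7 percentage points lower from compound 2 to compound 3 (beyond the scatter) at that carbon. Hydrogen in place of pyridin-2-yl on the saturated chain carbon bound to an amine nitrogen in a ring gives a number 23.4 percentage points lower from compound 1 to compound 3 (beyond the scatter) and so leaves compound 3 lowest of the three. Nothing at hand accounts for this drop.

The compounds shown leave open whether an ethyl or a benzyl on that piperazine nitrogen would stay close to compound 3 or to compounds 1 and 2. They also leave open how a morpholine at the same aromatic carbon would read.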